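The compounds below may be only part of what the source reports. "The series", "measured", "known", "first", "only" and "open" are said of these compounds alone.

Compound 1, `CCNC(=O)N[C@H]1[C@@H](O)[C@H](n2cnc3c(NC)ncnc32)O[C@@H]1C(=O)NC`: > 3000 nM
Compound 2, `CNC(=O)[C@H]1O[C@@H](n2cnc3c(NCc4cc(Cl)ccc4OC)ncnc32)[C@H](O)[C@@H]1N`: 15 nM

In an assay on isolated protein for binding affinity to adenosine receptor A3 (Homo sapiens) (on this read-out lower numbers stand for stronger inhibition and higher numbers for weaker inhibition), compound 1 gives > 3000 nM, which is a limit of the assay rather than a number. Going by the values given here, compound 2 gives 15 nM in this assay, and this is the only actual number among the two measurements. The other measurement sits at the limit of > 3000 nM in this assay, at which 1 of the 2 values shown sits. So compound 2 stands as the single reference point with a real value, with nothing measured beside it for comparison.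

Compound 3, `CNC(=O)[C@H]1O[C@@H](n2cnc3c(NCc4cc(Cl)ccc4OCc4ccccc4)ncnc32)[C@H](O)[C@@H]1N`, has not yet been measured. It differs from compound 2 in one place: phenyl in place of hydrogen on a saturated chain carbon bound to an oxygen on an aromatic ring. Among the compounds with values here, no pair of measured compounds differs in a single place, so no measured step shows what a change of this kind does in this assay. The expectation for compound 3 therefore rests on compound 2 alone, whose value of 15 nM is the starting point. The step expected here, a 2.7-fold higher number from compound 2 to compound 3 (0.43 log units; beyond the scatter), is modest and toward weaker binding, not clearly beyond the usual scatter. Compound 3 is estimated at 40 nM, within a range from 8 nM to 250 nM.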

Compound 3, inhibition constant: 16 nM
For compound 3 the middle estimate is 2.5-fold (0.40 log units) above the measured one; measured number inside the range.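

At the saturated chain carbon bound to an oxygen on an aromatic ring, putting phenyl in place of hydrogen, which turns methoxy into benzyloxy, gives in this assay a 1.1-fold higher number from compound 2 to compound 3 (0.03 log units; within the scatter), so the two compounds cannot be told apart on this read-out. Going by these compounds alone, this is the first step that can be read at this place: until now only one compound had a real value, and nothing showed whether the place would accept anything larger than that hydrogen. It now appears that, for this pair at least, a whole six-membered aromatic ring of carbon only can be added here with no difference beyond the usual scatter of repeated measurements.

What the compounds shown cannot say is why so large an addition leaves the reading where it was, and no measurement given here bears on that question. From the compounds shown here alone, it also stays open whether other groups at this place, such as an amine, a carboxylic acid or a longer chain ending in phenyl, would read the same way, as a single step cannot mark where the acceptance ends.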